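A few compounds are considered here, and "the series" means these few. Any claim that something is new, unique, unknown or untested is made for them only; others in the source may bear on it.

Three compounds of this series share one core and differ only in the aryl group on the carbon with a double bond to nitrogen. Compound 1 `O=C(CSc1nnc(-c2ccncc2)o1)N/N=C/c1ccc(F)cc1` gives 13500 nM in a functional assay on MCF7 cells (Homo sapiens) for cytotoxicity, read by MTT assay, with a stated time of 48 h; a lower number here means a stronger inhibitor, a higher number a weaker inhibitor. Compound 2 `O=C(CSc1nnc(-c2ccncc2)o1)N/N=C/c1cccc(F)c1` gives 24900 nM. Compound 3 `COc1cccc(/C=N/NC(=O)CSc2nnc(-c3ccncc3)o2)c1` gives 13800 nM; on these three numbers compound 3 stands second highest, nearest to compound 1 and furthest from compound 2, and all three values lie within the scatter of one another. The measured steps, a 1.8-fold higher number from compound 1 to compound 2 (0.27 log units; within the scatter), a 1.0-fold higher number from compound 1 to compound 3 (0.01 log units; within the scatter) and a 1.8-fold lower number from compound 2 to compound 3 (0.26 log units; within the scatter), are all within the scatter.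

Compound 4 `O=C(CSc1nnc(-c2ccncc2)o1)N/N=C/c1cc(Br)cc(Br)c1O` is not yet measured. It differs from compound 3 as follows: 3,5-dibromo-2-hydroxyphenyl in place of 3-methoxyphenyl on a carbon with a double bond to nitrogen. Among the compounds with values here, the steps that bear on this change are those that vary the same aryl group, a 1.0-fold higher number from compound 1 to compound 3 (0.01 log units; within the scatter) and a 1.8-fold lower number from compound 2 to compound 3 (0.26 log units; within the scatter), and neither moves the number beyond the scatter. Within the data shown here, no measured compound carries a hydroxyl or a bromine on that ring, so the change in compound 4 goes further than anything measured; on the data in hand the expectation is no step beyond the scatter, with a widened range to allow for the untested groups. Compound 4 is therefore expected to give about 11000 nM in this assay, between 3000 nM and 40000 nM, an expected step of a 1.3-fold lower number from compound 3 to compound 4 (0.10 log units; within the scatter).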

Compound 4, half-maximal inhibitory concentration: 9010 nM
Beside the measured number, compound 4's estimate is 1.2-fold (0.09 log units) above it; measured number inside the range.
By their numbers in this assay, from the lowest: compounds 4, 1, 3 and 2 (each within the scatter of the next, the first and the last beyond it).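

In this assay, within the data shown here, 3,5-dibromo-2-hydroxyphenyl is the first group at this position to carry a hydroxyl and bromine, and the number stays close to those of the simpler aryl groups: a 1.5-fold lower number from compound 3 to compound 4 (0.19 log units; within the scatter) and a 1.5-fold lower number from compound 1 to compound 4 (0.18 log units; within the scatter) both remain within the scatter. Among these compounds, the remaining step, a 2.8-fold lower number from compound 2 to compound 4 (0.44 log units; beyond the scatter), is the first to pass beyond the scatter, so this position can shift the number measurably, though only modestly and only between the two ends of the set, with compound 1 and compound 3 within the scatter of both. No evidence here bears on what lies behind this difference.

The hydroxyl and the two bromines enter together, so the compounds shown do not separate the contribution of each, and a ring with only the hydroxyl or only one bromine would be needed to do so. They also leave open how an amine or a carboxylic acid on this aryl ring would read in this assay, and whether any such group could take the number further than the modest step seen so far.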